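This account rests on a few compounds, and the source may have more. Where it says the series, first, only, none or still open, it means among the compounds named here.

In a functional assay on PC-3 cells (Homo sapiens) for antiproliferative activity, read by CCK-8 assay, with a stated time of 6 days (a higher number here means a weaker inhibitor, a lower number a stronger inhibitor), compound 1 `CCN(c1cccc(-c2ccccc2)c1)c1ccc(C#N)c(Cl)c1` has the entry "not determined" (no result reported). Compound 2 `CCN(c1ccc(C#N)c(Cl)c1)c1cc(-c2cncnc2)ccc1C` stands at > 30000 nM, which is a limit of the assay and not a number. Compound 3 `CCN(c1ccc(C#N)c(Cl)c1)c1cc(-c2ccc(F)nc2)ccc1C` gives > 30000 nM, which is also a limit. Both compounds sit at the limit described by the limit of > 30000 nM in this assay, at which 2 of the 3 values shown sit. Compound 4 `CCN(c1cccc(-c2cncnc2)c1)c1ccc(C#N)c(Cl)c1` departs from compound 2 by hydrogen in place of methyl on an aromatic carbon, with hydrogen in place of methyl on an aromatic carbon. For the measured compounds named here, the only measured step, a step that the two limits leave unreadable from compound 2 to compound 3, concerns a different change and offers no size or direction to carry over. Activity is therefore expected to stay close to that limit, with an expected step of a number no higher from compound 2 to compound 4 (the limit leaves the size open). Compound 4 is estimated at 30000 nM, within an expected range of 8000 nM to 100000 nM.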

Compound 4, half-maximal inhibitory concentration: > 30000 nM
Compound 4 was reported as a limit; the forecaster's own chance of this, stated with the estimate: 65%; the middle value sits exactly at the limit.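

For the compounds shown here, compound 2 and compound 4 both stand at a limit of this assay and not at a number, so no step between them can be read. As far as these compounds go, whether hydrogen in place of methyl changes antiproliferative activity at all stays open.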